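A few compounds are considered here, and "the series" means these few. Any claim that something is new, unique, unknown or untested is made for them only; others in the source may bear on it.

Measured in a functional assay on CWR22R cells (Homo sapiens) for antiproliferative activity, with a stated time of 96 h; on this read-out lower numbers stand for stronger inhibition and higher numbers for weaker inhibition:
compound 1 `Cc1cc(=O)oc2cc(OCC(=O)c3ccc4ccccc4c3)ccc12`: > 100000 nM (a limit)
compound 2 `Cc1cc(=O)oc2cc(OCC(=O)c3ccc(F)cc3)ccc12`: > 100000 nM (a limit)

Compound 2 stands at > 100000 nM as a limit of the assay and not a number. Compound 3 `Cc1cc(=O)oc2cc(OCC(=O)c3ccc(OC(F)(F)F)cc3)ccc12` carries trifluoromethoxy in place of fluoro on an aromatic carbon, para to a large group trifluoromethoxy in place of fluoro on an aromatic carbon with the shared core unchanged. Among the compounds with values here, no step between measured compounds is available, so the expectation rests on the limit of > 100000 nM in this assay, at which 2 of the 2 values shown sit, and no change beyond the scatter is expected in this assay for this replacement. The expected change is a number no higher from compound 2 to compound 3 (the limit leaves the size open) as estimated here. Compound 3 is estimated at 100000 nM with a range from 30000 nM to 200000 nM and is expected most likely to read as a limit again.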

Compound 3, half-maximal inhibitory concentration: > 100000 nM
Compound 3: only a limit was reported (the forecaster's own chance of this, stated with the estimate: 80%); the middle value lies on the limit itself.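

Within the data shown here, no step from compound 2 to compound 3 can be read in this assay: both values are limits of the assay and not numbers. The compounds shown leave open whether any replacement at this place changes the read-out, since none gives a number.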